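The source may hold more compounds than are shown below. What is called first, only, known or untested is meant among the compounds shown, and "the series" means these compounds.

In an assay on HEK293 cells for inhibition of Steryl-sulfatase (Homo sapiens), tested at 1 uM (a higher number here means a stronger effect of the compound at the concentration tested, a lower number a weaker effect), the measured compounds are: compound 1 `CCN(Cc1ccccn1)c1ccc(C(=O)N2CCc3ccc(OS(N)(=O)=O)cc3C2)cc1` with 87.7%; compound 2 `CCCN(CCC)c1ccc(C(=O)N2CCc3ccc(OS(N)(=O)=O)cc3C2)cc1` with 84.7%; compound 3 `CCN(Cc1ccccn1)c1cccc(C(=O)N2CCc3ccc(OS(N)(=O)=O)cc3C2)c1` with 19.9%.

From compound 1 to compound 2 the change is dipropylamino in place of ethyl((pyridin-2-yl)methyl)amino on an aromatic carbon, and it gave a number 3 percentage points lower from compound 1 to compound 2 (within the scatter). Compound 3 is built from the same atoms as compound 1, joined differently; how the two cores differ is not broken down here. Compound 4 `CCCN(CCC)c1cccc(C(=O)N2CCc3ccc(OS(N)(=O)=O)cc3C2)c1` has not been measured yet. It arises from compound 3 by dipropylamino in place of ethyl((pyridin-2-yl)methyl)amino on an aromatic carbon. This is the same kind of change as from compound 1 to compound 2, not the same: there the group sits para to a large group, here meta to a large group. The expectation rests on compound 3, which gives 19.9%, and on the earlier step, because a number 3 percentage points lower from compound 1 to compound 2 (within the scatter). The step from compound 3 to compound 4 is expected to be small, a number 1.9 percentage points lower from compound 3 to compound 4 (within the scatter), in this assay. Compound 4 is therefore estimated at 18%, likely between 5% and 38%.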

Compound 4, a percentage reported as inhibition, at one concentration (the size of the read-out at that concentration, not a potency): 54.8%
The estimate for compound 4 lay 36.8 percentage points below the measured number, outside the stated range (above it).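

In this assay, putting dipropylamino in place of ethyl((pyridin-2-yl)methyl)amino gave a number 34.9 percentage points higher from compound 3 to compound 4 (beyond the scatter), so the result of this change did not carry over unchanged from one core to the other: the same change on two cores in this assay, a number 3 percentage points lower (within the scatter) from compound 1 to compound 2 and a number 34.9 percentage points higher (beyond the scatter) from compound 3 to compound 4, 37.9 percentage points apart, beyond the scatter of two such steps. What the swap does in this series therefore depends on the core that carries it, and a result on one core is a poor guide to the other. Among these compounds, these are only two steps, so they show that the transfer can fail, but not why it failed or how any other replacement would behave on the two cores.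

From the compounds shown here alone, it remains open whether a shorter chain such as diethylamino, or an unsubstituted amine, would show the same gap between the two cores.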